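The source may report more compounds than this note shows. Statements on the series, on what has been measured and on what is new or still open speak of the compounds shown alone.

Compound 2 `O=C(COc1ccc2c(=O)ccoc2c1)Nc1cccc(NC(=O)c2ccc(F)cc2)c1`: 54 nM. Compound 1 `Cc1coc2cc(OCC(=O)Nc3cccc(NC(=O)c4ccc(N(C)C)cc4)c3)ccc2c1=O`: 2150 nM.

In an assay on isolated protein for inhibition of Rho-associated protein kinase 2 (Homo sapiens), read by scintillation counting, radiometric assay and 33P incorporation, with a stated time of 40 min, in the presence of a further agent that is not named here (on this read-out lower numbers stand for stronger inhibition and higher numbers for weaker inhibition), compound 2 gives the lowest of the two numbers measured; compound 1 gives a markedly higher number, beyond the usual scatter. Compound 3 `O=C(COc1ccc2c(=O)ccoc2c1)Nc1cccc(NC(=O)c2ccc(C(=O)O)cc2)c1` differs from compound 2 in one place: carboxy in place of fluoro on an aromatic carbon. Among the measured compounds shown here, no single-change step between measured compounds is available to anchor this change, and compound 1 differs from compound 2 in more than one place. A step toward weaker inhibition, beyond the scatter, is expected. Compound 3 is therefore estimated at 250 nM, within 50 nM to 1500 nM. The expected step is a 4.6-fold higher number from compound 2 to compound 3 (0.67 log units; beyond the scatter).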

Compound 3, half-maximal inhibitory concentration: 2030 nM
For compound 3 the middle estimate is 8.1-fold (0.91 log units) below the measured one, outside the stated range (above it).
By their numbers in this assay, from the lowest: compound 2; then compounds 3 and 1 (each within the scatter of the next).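

Among the compounds shown here, the change from 4-fluorophenyl to 4-carboxyphenyl gives a 38-fold higher number from compound 2 to compound 3 (1.58 log units; beyond the scatter) in this assay and is the first single-change step available here. It shows that inhibition depends strongly on the group at this aromatic carbon, para to a large group. No measurement offered here accounts for the size of this step. On these data alone, whether a methyl ester, a primary amide or an amine would give a similar step remains open. So does what hydrogen in place of fluoro would give at this position.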